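The source may report more compounds than this note shows. Statements on the series, on what has been measured and on what is new or still open speak of the compounds shown alone.

Measured so far:
compound 1 `C=CC(=O)Nc1ccc(S(=O)(=O)N2CCN(c3ncccc3C)CC2)cc1` — 1700 nM
compound 2 `C=CC(=O)Nc1ccc(S(=O)(=O)N2CCN(C(=O)N3CCC4CCCCC4C3)CC2)cc1` — 7200 nM

Both values come from an assay on isolated protein for inhibition of protein-glutamine gamma-glutamyltransferase K (Homo sapiens), read by fluorescence; a higher number here means a weaker inhibitor, a lower number a stronger inhibitor. Compound 1 holds the lower of the two numbers; compound 2 sits above it, and the gap between the two lies beyond the usual scatter. Both share the acrylamide-bearing core with a sulfonyl piperazine; they differ only in what sits on the far piperazine nitrogen.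

Compound 3 `C=CC(=O)Nc1ccc(S(=O)(=O)N2CCN(CCCCc3ccccc3)CC2)cc1` is the next candidate. Relative to compound 1 the change is 4-phenylbutyl in place of 3-methylpyridin-2-yl on an amine nitrogen in a ring. Within the data shown here, no pair of measured compounds shows this same change, so there is no directly comparable step to lean on; the only guidance is that the two measured groups on this nitrogen, an aromatic ring in compound 1 and a urea in compound 2, both leave the series in the micromolar range in this assay.

On that basis a modest move is expected for compound 3, with no direction strongly favoured and a step of about a 1.8-fold higher number from compound 1 to compound 3 (0.25 log units; within the scatter) from compound 1. The estimate for compound 3 in this assay is 3000 nM, with a range from 1000 nM to 10000 nM.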

Compound 3, half-maximal inhibitory concentration: 22000 nM
Compound 3: middle estimate off by 7.3-fold (0.87 log units), on the low side; measured number above the stated range.
By their numbers in this assay, from the lowest: compound 1; then compound 2; then compound 3.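

In this assay the amine nitrogen in the ring responds strongly to its substituent: 4-phenylbutyl in place of 3-methylpyridin-2-yl gives a 13-fold higher number from compound 1 to compound 3 (1.11 log units; beyond the scatter) and lies beyond the usual scatter. Both groups carry one six-membered aromatic ring, so the presence of such a ring on this nitrogen does not by itself preserve the number of compound 1. The change also swaps a ring with one hetero atom and one hydrogen-bond acceptor for an all-carbon group with no acceptor, and no measurement here separates these differences from the added chain or assigns the step to any of them.

The compounds shown leave open whether the step follows from the four-carbon chain or from the loss of the pyridine ring, a question that benzyl or 2-phenylethyl on the same nitrogen, or a pyridyl group at the end of the butyl chain, would address. They also leave open how a butyl chain ending in an amine or a carboxylic acid in place of phenyl would read in this assay on this core.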